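Aryl ether variation on the coumarin-linked series

A few compounds are considered here, and "the series" means these few. Any claim that something is new, unique, unknown or untested is made for them only; others in the source may bear on it.

Measured compounds:
compound 1 `Cc1nn(C)c(Oc2ccc(F)cc2F)c1/C=N\CCCCCCOc1cc2oc(=O)cc(C)c2cc1Cl` — > 25000 nM
compound 2 `Cc1nn(C)c(Oc2ccc(Br)cc2)c1/C=N\CCCCCCOc1cc2oc(=O)cc(C)c2cc1Cl` — 4630 nM
compound 3 `Cc1ccccc1Oc1c(/C=N\CCCCCCOc2cc3oc(=O)cc(C)c3cc2Cl)c(C)nn1C` — 7830 nM

In a functional assay on HepG2 cells (Homo sapiens) for antiproliferative activity, read by MTT assay, with a stated time of 72 h (on this read-out lower numbers stand for stronger inhibition and higher numbers for weaker inhibition), compound 1 gives only > 25000 nM, which is a limit of the assay and not a number (the limit of > 25000 nM in this assay, at which 1 of the 3 values shown sits). Compound 2 gives 4630 nM and compound 3 gives 7830 nM; these two lie within the scatter of each other a 1.7-fold higher number from compound 2 to compound 3 (0.23 log units; within the scatter).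

Compound 4 `Cc1nn(C)c(Oc2ccc(OC(F)(F)F)cc2)c1/C=N\CCCCCCOc1cc2oc(=O)cc(C)c2cc1Cl` differs from compound 1 as follows: 4-(trifluoromethoxy)phenyl in place of 2,4-difluorophenyl on an oxygen on an aromatic ring. Within the data shown here, the steps that bear on it are an at least 5.3-fold lower number from compound 1 to compound 2 (0.73 log units; beyond the scatter) and an at least 3.1-fold lower number from compound 1 to compound 3 (0.50 log units; beyond the scatter), both replacing the same 2,4-difluorophenyl and both giving a lower number beyond the scatter. A comparable lower number is therefore expected: for compound 4 the estimate is 6000 nM, ranging from 2500 nM to 20000 nM, meaning an expected step of an at least 4.1-fold lower number from compound 1 to compound 4 (0.61 log units; beyond the scatter).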

Compound 4, half-maximal inhibitory concentration: 8160 nM
Beside the measured number, compound 4's estimate is 1.4-fold (0.13 log units) below it; the measured number falls inside the stated range.
By their numbers in this assay, from the lowest: compounds 2, 3 and 4 (each within the scatter of the next). At a limit, above all of these: compound 1.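

In this assay, a third replacement of the 2,4-difluorophenyl group also lowers the number: an at least 3.0-fold lower number from compound 1 to compound 4 (0.48 log units; beyond the scatter). The value of compound 1 is a limit and not a number: the limit of > 25000 nM in this assay, at which 1 of the 4 values shown sits. Trifluoromethoxy in place of bromo gives a 1.8-fold higher number from compound 2 to compound 4 (0.25 log units; within the scatter), and 4-(trifluoromethoxy)phenyl in place of 2-methylphenyl gives a 1.0-fold higher number from compound 3 to compound 4 (0.02 log units; within the scatter), so these three aryl groups cannot be told apart at this position.

Going by these compounds, whether an amine or a carboxylic acid on this aryl ring would move the number beyond the scatter remains open. The compounds shown also cannot say whether the limit seen with compound 1 follows from having two fluorines or from where they sit.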